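This account rests on a few compounds, and the source may have more. Where it says the series, first, only, none or still open, it means among the compounds named here.

Compounds measured so far in a functional assay on HEK293 cells for antagonist activity at metabotropic glutamate receptor 5 (Rattus norvegicus), read by calcium flux; a lower number here means a stronger inhibitor, a higher number a weaker inhibitor:

- compound 1, `Cc1nc(C#Cc2cc(Br)cc([N+](=O)[O-])c2)cs1`: 0.73 nM
- compound 2, `Cc1nc(C#Cc2cc(I)cc(C#N)c2)cs1`: 1.05 nM
- compound 3, `Cc1nc(C#Cc2cc(F)cc([N+](=O)[O-])c2)cs1`: 0.61 nM

Compound 3 has the lowest of the three numbers, but its distance to compound 1 and to compound 2 lies within the scatter, so no order among the three can be read from these values.

Compound 4, `Cc1nc(C#Cc2cc(I)cc([N+](=O)[O-])c2)cs1`, has not been measured yet. It differs from compound 3 in one place: iodo in place of fluoro on an aromatic carbon.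

Among the compounds with values here, only one measured step bears directly on this change, the halogen swap on the same aromatic carbon with the nitro group kept: a 1.2-fold lower number from compound 1 to compound 3 (0.08 log units; within the scatter). Two halogens of very different size at that position gave values within the scatter of each other. Within the data shown here, compound 2 carries iodo at the same place but nitrile instead of nitro, so no single-change step links it to compound 3 or compound 4; its value in this assay sits close to that of compound 1 and compound 3.

Given that, no shift beyond the scatter is expected from compound 3 to compound 4; the estimated step is a 1.1-fold higher number from compound 3 to compound 4 (0.06 log units; within the scatter). Compound 4 is estimated at 0.7 nM, with the range 0.3 nM to 1.6 nM.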

Compound 4, half-maximal inhibitory concentration: 1.75 nM
The estimate for compound 4 lay 2.5-fold (0.40 log units) below the measured number; the measured number lies above the stated range.
By their numbers in this assay, from the lowest: compounds 3, 1, 2 and 4 (each within the scatter of the next, the first and the last beyond it).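

In this assay, within the data shown here, with the nitro group kept, iodo at this aromatic carbon is the first halogen to move the number beyond the scatter: a 2.9-fold higher number from compound 3 to compound 4 (0.46 log units; beyond the scatter) and a 2.4-fold higher number from compound 1 to compound 4 (0.38 log units; beyond the scatter) are both modest steps, while fluoro and bromo remain within the scatter of each other in a 1.2-fold lower number from compound 1 to compound 3 (0.08 log units; within the scatter). With iodo kept, the exchange of nitrile for nitro gives a 1.7-fold higher number from compound 2 to compound 4 (0.22 log units; within the scatter) and so shows no change at the other substituted carbon. Nothing measured here explains the iodo step.

The compounds shown leave open whether fluoro or bromo would give the same result alongside nitrile as alongside nitro. They also leave open how an amine or a carboxylic acid on this aromatic carbon would compare with the halogens.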